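From compound 1 to compound 4

This account rests on a few compounds, and the source may have more. Where it says the series, first, only, none or still open, it means among the compounds named here.

Values measured so far in a physicochemical assay, with a stated time of 30 min (on this read-out lower numbers stand for stronger inhibition and higher numbers for weaker inhibition), are these:
Compound 1 (`COc1cc(COc2ccc(C(=O)NN)cc2)cc(OC)c1OC`) gives 264 ug/mL as a number.
Compound 2 (`COc1cc(COc2ccc(C(=O)N/N=C/c3cc(Br)cc(Cl)c3O)cc2)cc(OC)c1OC`) gives > 100 ug/mL as a limit.
Compound 3 (`COc1cc(/C=N/NC(=O)c2ccc(OCc3cc(OC)c(OC)c(OC)c3)cc2)cc(OC)c1O`) gives 75 ug/mL as a number.

Compound 1 has the higher of the two actual numbers, and compound 3 lies lower by a margin beyond the usual scatter. The value of compound 2 is a limit and not a number.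

Compound 4 (`COc1cc(COc2ccc(C(=O)N/N=C/c3ccccc3O)cc2)cc(OC)c1OC`) has not yet been measured. It differs from compound 1 on an amide-type nitrogen (a group of 9 heavy atoms (7 carbon, 1 nitrogen, 1 oxygen; one six-membered aromatic ring of carbon only) in place of one nitrogen atom, on an amide-type nitrogen), where a group of 9 heavy atoms, with one six-membered aromatic ring of carbon only, stands in place of one nitrogen atom.

Among the compounds with values here, two measured steps bear on this change. The step that the limit leaves unreadable from compound 1 to compound 2 is a change at the same place, yet because of the limit of > 100 ug/mL in this assay, at which 1 of the 3 values shown sits, it offers no size. The step of an at least 1.3-fold lower number from compound 2 to compound 3 (0.12 log units; that floor lies within the scatter) swaps the aromatic group on a carbon with a double bond to nitrogen, and its floor lies within the scatter. Within the data shown here, compound 3 at 75 ug/mL gives the only actual number for a compound carrying a group of this kind, and that number is lower than the one for compound 1. A lower number is therefore expected after the change. In this assay the expected step is a 2.4-fold lower number from compound 1 to compound 4 (0.38 log units; beyond the scatter) and its size remains uncertain. For compound 4 the estimated value is 110 ug/mL with an expected range from 45 ug/mL to 270 ug/mL in this measurement.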

Compound 4, half-maximal inhibitory concentration: > 100 ug/mL
Compound 4 ended at the assay's limit (the forecaster's own chance of this, stated with the estimate: 35%); the middle value is on the limit's open side.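

In this assay, within the data shown here, compound 4 gives > 100 ug/mL, which is a limit and not a number, so 2-hydroxyphenyl on the carbon with a double bond to nitrogen gives no readable value, and compound 3 remains the only compound with an aromatic group at this place that has an actual number. Putting 2-hydroxyphenyl in place of 4-hydroxy-3,5-dimethoxyphenyl amounts to an at least 1.3-fold higher number from compound 3 to compound 4 (0.12 log units; that floor lies within the scatter), so the limit does not establish a real difference between these two groups, although it leaves room for one. The steps to compound 4 from compound 1 and from compound 2 cannot be read: the limit of > 100 ug/mL in this assay, at which 2 of the 4 values shown sit.

On these data alone, whether replacing the amino group of compound 1 with the 2-hydroxyphenyl-bearing group lowers or raises the number therefore stays open, as does the true size of the step from compound 3 to compound 4. Also open is how the read-out would respond to an amine or a carboxylic acid in place of the hydroxy group on this aromatic ring, since the compounds shown carry neither group there.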